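A Missing Baseline and an Ethyl Swap

The source may hold more compounds than are shown below. What is called first, only, known or untested is meant among the compounds shown, and "the series" means these compounds.

Compound 1 `Cc1ccc2c(c1C)CN(C(C)C)CC2c1ccccc1`: 6280 nM
Compound 2 `CN(C)C(=O)N1Cc2c(F)cccc2C(c2cccc(O)c2)C1`: "not determined" (no result reported)

The measurements come from a functional assay on A2780 cells (Homo sapiens) for antiproliferative activity (a lower number here means a stronger inhibitor, a higher number a weaker inhibitor), and they are few. Only compound 1 carries a number there. For compound 2 the entry reads "not determined" (no result reported) and gives no result, so it offers no position on the scale and no comparison with compound 1 can be drawn.

Compound 3 `CCc1cccc2c1CN(C(=O)N(C)C)CC2c1cccc(O)c1` has yet to be tested. The structural change leading to it is ethyl in place of fluoro on an aromatic carbon and amounts to ethyl in place of fluoro on an aromatic carbon, ortho to a fused ring and meta to a fused ring. The rest of the structure, including the hydroxyl-bearing phenyl group and the urea, stays the same.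

For the measured compounds named here, no measured step shows what such an exchange does, and without a number for compound 2 the size and direction of the step cannot be derived. Going by the values given here, the only anchor is compound 1 at 6280 nM and it has a different substitution, so a wide range is expected, centred somewhat on the stronger side of that value. The estimated value for compound 3 in this assay is 1500 nM with an expected range from 150 nM to 12000 nM overall.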

Compound 3, half-maximal inhibitory concentration: 186 nM
For compound 3 the middle estimate is 8.1-fold (0.91 log units) above the measured one; the range from low to high includes it.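

In this assay, for the compounds shown here, compound 3 gives 186 nM but compound 2 has no single number there, and no step from compound 2 to compound 3 can be read. From the compounds shown here alone, what the exchange of fluoro for ethyl does to activity stays open. No available evidence bears on this result.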